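Urea Aryl Exchange on a Shared Lactone Core

The source may hold more compounds than are shown below. What is called first, only, known or untested is meant among the compounds shown, and "the series" means these compounds.

The series rests on a shared core and is followed in a functional assay on cells (T-cell, Mus musculus) for inhibition; on this read-out lower numbers stand for stronger inhibition and higher numbers for weaker inhibition. Compound 1 `N#Cc1ccc(/C=C/C(=O)Nc2ccc3c(c2)COC3=O)cc1` carries an acrylamide link and gives 43100 nM. Compound 2 `Cc1ccccc1NC(=O)Nc1ccc2c(c1)COC2=O` carries a urea link and gives 900 nM, the lowest of the two numbers measured; the nearest, compound 1, stands beyond the scatter above it. From the compounds shown here alone, the change of 2 into 3 is not paired with a measured step, so its size is unknown. Compound 3 `O=C(Nc1ccc(I)cc1)Nc1ccc2c(c1)COC2=O` is the urea with 4-iodophenyl in place of 2-methylphenyl on an amide-type nitrogen. Because compound 2 shows 900 nM and the urea link is kept, the step from compound 2 to compound 3 is expected to be small, with a 1.7-fold higher number from compound 2 to compound 3 (0.22 log units; within the scatter) likely within or only slightly beyond the scatter, direction uncertain. Compound 3 is estimated at 1500 nM in this assay, with a range from 300 nM to 8000 nM.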

Compound 3, half-maximal inhibitory concentration: 1370 nM
Compound 3: the middle estimate sits 1.1-fold (0.04 log units) above what was measured; low and high end bracket the measured number.
By their numbers in this assay, from the lowest: compounds 2 and 3 (each within the scatter of the next); then compound 1.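

In this assay, the exchange on the amide-type nitrogen of the urea gives a 1.5-fold higher number from compound 2 to compound 3 (0.18 log units; within the scatter), so 4-iodophenyl in place of 2-methylphenyl leaves the two ureas indistinguishable on this read-out. Among these compounds, this is the first reading at this position, and it shows that the number holds through a swap of one substituted aryl ring for another, although the substituent and its place on the ring both differ, so the two contributions cannot be separated. No measurement is at hand that bears on why the two compounds read alike.

From the compounds shown here alone, how plain phenyl would read here stays open, and with it whether a substituent on this ring matters at all. Also open, going by these compounds, is whether a ring bearing an amine or a carboxylic acid, or a longer chain in place of the ring, would keep the number in this range.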